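Series notes: compound 1 to compound 4 in cytotoxicity

The source may report more compounds than this note shows. Statements on the series, on what has been measured and on what is new or still open speak of the compounds shown alone.

Compound 1 `CSc1ccc(NC(=O)Nc2cc(C)nc3ccccc23)cc1` was run in an ADME assay on Raji cells (Homo sapiens) for cytotoxicity, with a stated time of 72 h; a lower number here means that less compound is needed, a higher number that more compound is needed for the effect. In this assay compound 1 gives only a limit, > 25000 nM, and not a number. Compound 2 `Cc1cc(NC(=O)Nc2ccccc2C(C)(C)C)c2ccccc2n1` likewise returns a limit in this assay, > 25000 nM. Compound 3 `COC(=O)c1cccc(NC(=O)Nc2cc(C)nc3ccccc23)c1` gives a measured number in this assay, 26000 nM. No step between two measured compounds is available, and compound 1 is not set apart from the others on the numbers shown; what there is reads (the limit of > 25000 nM in this assay, at which 2 of the 3 values shown sit). Compound 4 `Cc1cc(NC(=O)Nc2ccc(SC(F)(F)F)cc2)c2ccccc2n1` is the next member awaiting measurement in this assay. It differs from compound 1 by trifluoromethyl in place of methyl on a sulfur, the same difference read one bond further out as methylsulfanyl to (trifluoromethyl)sulfanyl. The step is expected to be a step that the limit leaves unreadable from compound 1 to compound 4, nothing beyond the scatter, most likely another limit. Compound 4 is estimated at 30000 nM, with a range from 12000 nM to 80000 nM.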

Compound 4, half-maximal effective concentration: 10000 nM
The estimate for compound 4 lay 3.0-fold (0.48 log units) above the measured number; measured number outside the range, below it.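

In this assay, among these compounds, trifluoromethyl in place of methyl on a sulfur gives an at least 2.5-fold lower number from compound 1 to compound 4 (0.39 log units; beyond the scatter), the first readable step. This shows that a change at this sulfur can move the number beyond the scatter. Compound 4 gives a measured number, but compound 1 gives only a limit, so the full size of the step stays unknown: the limit of > 25000 nM in this assay, at which 2 of the 4 values shown sit.

From the compounds shown here alone, whether an ethyl chain or an amine at this place would move the number the same way remains open. Going by these compounds, whether the three fluorine atoms act together or singly also remains open.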